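This account rests on a few compounds, and the source may have more. Where it says the series, first, only, none or still open, it means among the compounds named here.

Measured so far:
- compound 1 `O=S(=O)(c1ccc(F)cc1)c1nc2ccccc2nc1N1CCCC(O)C1`: 18300 nM
- compound 2 `O=S(=O)(c1ccccc1)c1nc2ccccc2nc1N1CCC(O)CC1`: 5360 nM

In a functional assay on KB cells (Homo sapiens) for cytotoxicity, read by MTT assay, with a stated time of 72 h (on this read-out higher numbers stand for weaker inhibition and lower numbers for stronger inhibition), compound 2 gives 5360 nM, the lower of the two numbers. Compound 1 gives 18300 nM, and the gap between them lies beyond the usual scatter. Within the data shown here, with only two values, compound 2 has a single neighbour on this scale.

The next compound is compound 3 `O=S(=O)(c1ccc(F)cc1)c1nc2ccccc2nc1N1CCC(O)CC1`, which departs from compound 2 in one place: fluoro in place of hydrogen on an aromatic carbon. This is fluoro in place of hydrogen on an aromatic carbon, or phenyl to 4-fluorophenyl.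

Among the measured compounds shown here, no measured pair differs in one place alone, so the size of this change in this assay has no direct precedent. Compound 1 also carries the 4-fluorophenyl and stands at 18300 nM, which gives a slight lean towards a higher number, though that single value cannot isolate the group. The expected 1.3-fold higher number from compound 2 to compound 3 (0.12 log units; within the scatter) is small, within the scatter, and if anything towards weaker inhibition. For compound 3 the estimated value is 7000 nM, with an expected range of 2500 nM to 18000 nM.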

Compound 3, half-maximal inhibitory concentration: 9580 nM
For compound 3 the middle estimate is 1.4-fold (0.14 log units) below the measured one; the range from low to high includes it.
By their numbers in this assay, from the lowest: compounds 2, 3 and 1 (each within the scatter of the next, the first and the last beyond it).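

In this assay, the single-place pair on the aromatic ring gives a 1.8-fold higher number from compound 2 to compound 3 (0.25 log units; within the scatter), so on this read-out fluoro in place of hydrogen on an aromatic carbon, phenyl to 4-fluorophenyl, cannot be told apart from no change. The pair that keeps the 4-fluorophenyl gives a 1.9-fold lower number from compound 1 to compound 3 (0.28 log units; within the scatter) for 4-hydroxypiperidin-1-yl in place of 3-hydroxypiperidin-1-yl, so moving to this group also stays inside what repeated measurements would show. No measured property of these compounds bears on the size of either step.

Each step rests on one pair, so neither shows how a different group on this aromatic carbon, such as chloro, methoxy or an amine, would read in this assay. Also open, from the compounds shown here alone, is how a morpholine or a piperidine-4-carboxylic acid in place of the 4-hydroxypiperidin-1-yl would read against compound 3 at 9580 nM.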